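The source may hold more compounds than are shown below. What is called first, only, known or untested is meant among the compounds shown, and "the series" means these compounds.

For the measured compounds named here, compound 2 `COc1cccc(-c2ccc(OC)c(S(=O)(=O)Nc3cccc(NCCNC(=O)c4ccccc4OC)c3)c2)c1` is the only compound here with an actual number in an assay on CHO-K1 cells for agonist activity at Orexin receptor type 2 (Homo sapiens), read by a luciferase reporter (on this read-out higher numbers stand for an effect only at larger amounts of compound and lower numbers for an effect already at smaller amounts), where compound 2 gives 800 nM. Compound 1 `COc1ccccc1C(=O)NCCNc1cccc(NS(=O)(=O)c2cc(-c3ccccc3)ccc2OC)c1` reaches only the limit of this assay, giving > 10000 nM. The step of an at least 12-fold lower number from compound 1 to compound 2 (1.09 log units; beyond the scatter) is a large gain when a methoxy enters this aromatic carbon, though the comparison rests on a limit (the limit of > 10000 nM in this assay, at which 1 of the 2 values shown sits). Compound 3 `COC(=O)c1cccc(-c2ccc(OC)c(S(=O)(=O)Nc3cccc(NCCNC(=O)c4ccccc4OC)c3)c2)c1` carries methoxycarbonyl in place of methoxy on an aromatic carbon. Going by the values given here, no measured step swaps one substituent for another at this carbon, so only a modest change is expected. Compound 3 is estimated at 1000 nM in this assay, between 300 nM and 4000 nM, a step of a 1.3-fold higher number from compound 2 to compound 3 (0.10 log units; within the scatter) that is expected to stay within the scatter.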

Compound 3, half-maximal effective concentration: > 10000 nM
Compound 3: only a limit was reported; the forecaster's own chance of this, stated with the estimate: 15%; middle value at least 10-fold (1.00 log units) away from the limit.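

In this assay, replacing methoxy with methoxycarbonyl gives an at least 12-fold higher number from compound 2 to compound 3 (1.09 log units; beyond the scatter). This shows that the gain seen with methoxy at this aromatic carbon does not carry over to every larger oxygen-containing group. The value of compound 3 is a limit, so the full size of this loss and the step between compound 1 and compound 3 cannot be read: the limit of > 10000 nM in this assay, at which 2 of the 3 values shown sit.

On these data alone, whether an amine, a hydroxyl or a carboxylic acid at this carbon would give a measurable number stays open. So does whether methoxy would give a similar gain on other carbons of this ring.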